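Compound 3 without its 5-methylthiophen-2-yl group

The source may report more compounds than this note shows. Statements on the series, on what has been measured and on what is new or still open speak of the compounds shown alone.

Of the compounds shown here, three have been measured in a functional assay on MCF7 cells (Homo sapiens) for antiproliferative activity, read by MTT assay, with a stated time of 48 h; on this read-out higher numbers stand for weaker inhibition of growth and lower numbers for stronger inhibition of growth. Compound 1 (`CCOc1cc(NC(=O)CCCCC(=O)Nc2cc(-c3ccccc3)ccc2N)cc2c1OCC([N+](=O)[O-])=C2`) gives 19900 nM. Compound 2 (`CCOc1cc(NC(=O)CCCCCCC(=O)Nc2cc(-c3ccccc3)ccc2N)cc2c1OCC([N+](=O)[O-])=C2`) differs from compound 1 in its chain, and compound 2 gives 9370 nM. Compound 3 (`CCOc1cc(NC(=O)CCCCC(=O)Nc2cc(-c3ccc(C)s3)ccc2N)cc2c1OCC([N+](=O)[O-])=C2`) gives 7910 nM. Compound 3 thus stands with compound 2 at the low end of the three numbers, the two lying within the scatter of each other, while compound 1 lies beyond the scatter from compound 3.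

Compound 4 (`CCOc1cc(NC(=O)CCCCC(=O)Nc2ccccc2N)cc2c1OCC([N+](=O)[O-])=C2`) has not yet been measured. It has hydrogen in place of 5-methylthiophen-2-yl on an aromatic carbon.

Going by the values given here, only one measured step bears on this change, and it exchanges one group for another rather than removing one. That step, a 2.5-fold lower number from compound 1 to compound 3 (0.40 log units; beyond the scatter), is modest and comes from 5-methylthiophen-2-yl replacing phenyl. Among the compounds with values here, no measured pair shows what happens when such a group is lost altogether, so the size of the coming step is poorly fixed. A modest rise in the number, similar in size to that step, seems the likeliest outcome, meaning weaker inhibition of growth. The expected change is a 2.1-fold higher number from compound 3 to compound 4 (0.33 log units; beyond the scatter). Compound 4 is estimated at 17000 nM, with an expected range of 6000 nM to 45000 nM.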

Compound 4, concentration for 50% growth inhibition: 17300 nM
For compound 4 the middle estimate is 1.0-fold (0.01 log units) below the measured one; low and high end bracket the measured number.
By their numbers in this assay, from the lowest: compounds 3, 2, 4 and 1 (each within the scatter of the next, the first and the last beyond it).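

In this assay, removing 5-methylthiophen-2-yl from the aromatic carbon para to an amino group gives a 2.2-fold higher number from compound 3 to compound 4 (0.34 log units; beyond the scatter), so the lower number seen with this group is lost when the position carries only hydrogen. Hydrogen in place of phenyl at the same carbon gives a 1.2-fold lower number from compound 1 to compound 4 (0.06 log units; within the scatter), which lies within the scatter; the earlier comparison of the two aromatic groups could not show this, and here phenyl cannot be told apart from hydrogen, while among these three compounds with the shorter chain only the 5-methylthiophen-2-yl compound stands apart. Nothing available for these compounds accounts for the difference between the two aromatic groups.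

Going by these compounds, it remains open whether the lower number depends on the methyl group or on the sulfur-containing ring, which a plain thiophen-2-yl group or a small methyl group alone at this carbon would help to separate. It is also open whether the same order of groups would hold on the longer chain of compound 2, where neither hydrogen nor 5-methylthiophen-2-yl appears among the compounds shown.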